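The source may report more compounds than this note shows. Statements on the series, on what has been measured and on what is new or still open speak of the compounds shown alone.

Working notes on the series. Compound 1 `COc1cc(OC)c2c(=O)cc(-c3ccccc3)oc2c1I` and compound 2 `CC(=O)Oc1cc(OC(C)=O)c2c(=O)cc(-c3ccccc3)oc2c1` share the same core. In a functional assay on HT-29 cells (Homo sapiens) for inhibition (a lower number here means a stronger inhibitor, a higher number a weaker inhibitor), compound 1 gives 2600 nM. In this assay compound 2 gives 2600 nM, level with compound 1 within the scatter, so the two values show no change between them. Compound 3 `CC(=O)Oc1cc(O)c2c(=O)cc(-c3ccccc3)oc2c1` is still to be run in this assay. Compound 3 differs from compound 2 by hydrogen in place of acetyl on an oxygen on an aromatic ring. For the measured compounds named here, no measured step covers that change. The step of a 1.3-fold lower number from compound 2 to compound 3 (0.11 log units; within the scatter) is expected to stay within the scatter, leaning if anything toward a slightly stronger inhibitor. Compound 3 is accordingly estimated at 2000 nM, with a range from 700 nM to 6000 nM.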

Compound 3, half-maximal inhibitory concentration: 3800 nM
Estimate against measurement, compound 3: 1.9-fold (0.28 log units) below, within the range that was stated.
By their numbers in this assay, from the lowest: compounds 1, 2 and 3 (each within the scatter of the next).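

In this assay, the first step read at this position, acetoxy to hydroxy on an oxygen on an aromatic ring, is a 1.5-fold higher number from compound 2 to compound 3 (0.16 log units; within the scatter), so removing the acetyl leaves compound 3 within the scatter of compound 2. For this single pair, a free hydroxy and an acetoxy at this place cannot be told apart by this read-out. Nothing on hand gives a reason for this result.

On these data alone, whether a longer chain such as butyryl, or a methyl ether, on this oxygen would stay within the same scatter remains open. As far as these compounds go, an amine in place of this oxygen also remains untested by these compounds.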